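The source may hold more compounds than are shown below. What is called first, only, known or untested is meant among the compounds shown, and "the series" means these compounds.

Compound 1 `COc1ccc(Nc2ncc3c(n2)CCC3)cc1`: 840 nM
Compound 2 `O=C(Nc1cccc(CN2CCCC2)c1)c1n[nH]c2ccccc12`: 8620 nM
Compound 3 `COc1cccc(Nc2ncc3c(n2)CCCC3)c1`: 2280 nM

These three compounds were tested in a functional assay on MV4-11 cells (Homo sapiens) for inhibition, read by resazurin assay, with a stated time of 72 h; on this read-out higher numbers stand for weaker inhibition of growth and lower numbers for stronger inhibition of growth. Compound 3 holds the second highest of the three numbers. It sits above compound 1 and below compound 2, and both gaps lie beyond the scatter.

Compound 4 `Cc1cccc(Nc2ncc3c(n2)CCCC3)c1` has methyl in place of methoxy on an aromatic carbon, meta to a large group (methyl in place of methoxy on an aromatic carbon). Going by the values given here, the measured compounds include no pair that differs in only one place, so they give no direct guide to the size of this change. No step beyond the scatter is expected in this assay, and neither direction is favoured. Among the compounds with values here, this expectation starts from compound 3 at 2280 nM, the only measured compound with the same core as compound 4. The estimated change is a 1.1-fold higher number from compound 3 to compound 4 (0.04 log units; within the scatter), which would stay within the scatter. For compound 4 the expected value is 2500 nM, with an estimated range from 1000 nM to 6000 nM.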

Compound 4, concentration for 50% growth inhibition: 3290 nM
Compound 4: middle estimate off by 1.3-fold (0.12 log units), on the low side, within the range that was stated.
By their numbers in this assay, from the lowest: compound 1; then compounds 3 and 4 (each within the scatter of the next); then compound 2.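

Going by these compounds alone, the swap of methoxy for methyl on an aromatic carbon, meta to a large group, gives a 1.4-fold higher number from compound 3 to compound 4 (0.16 log units; within the scatter) in this assay and is the first step in this set that changes one place only. It shows that, on this core and at this position, the two groups cannot be told apart on this read-out, even though the methoxy carries a hydrogen-bond acceptor and the methyl carries none. Nothing measured here explains this result.

The compounds shown leave open whether another group at this carbon, such as an amine, a carboxylic acid or a longer chain, would produce a step beyond the scatter. They also leave open whether the same swap would give a similar step on the core of compound 1.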